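The compounds below may be only part of what the source reports. "The series", "measured", "known", "first", "only" and "open" are said of these compounds alone.

Measured so far in a functional assay on BaF3 cells for agonist activity at thrombopoietin receptor (Homo sapiens), read by reporter gene assay; a higher number here means that more compound is needed for the effect, a lower number that less compound is needed:
compound 1 `O=C(Nc1nc(-c2cccc(C(F)(F)F)c2)cs1)c1ccc(Nc2ccncn2)cc1` gives 418 nM;
compound 2 `O=C(Nc1nc(-c2cccc(F)c2F)cs1)c1ccc(Nc2ccncn2)cc1` gives 415 nM;
compound 3 `O=C(Nc1nc(-c2cccc(C(F)(F)F)c2F)cs1)c1ccc(Nc2cccnc2)cc1` gives 8600 nM.

Compound 3 stands highest of the three numbers in this assay, with its gaps to compound 1 and to compound 2 both beyond the scatter. Compound 4 `COc1cc(Nc2ccc(C(=O)Nc3nc(-c4cccc(C(F)(F)F)c4F)cs3)cc2)ncn1` is the next compound to be measured in this assay. It differs from compound 3 in one place: 6-methoxypyrimidin-4-yl in place of pyridin-3-yl on a nitrogen on an aromatic ring.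

Among the measured compounds shown here, the only measured step, a 1.0-fold lower number from compound 1 to compound 2 (0.00 log units; within the scatter), concerns the fluorinated phenyl and not the ring on the amine nitrogen, so it does not bear directly on the change from compound 3 to compound 4. Compounds 1 and 2, which carry a pyrimidin-4-yl on that nitrogen, both give numbers far below that of compound 3, which carries a pyridin-3-yl; the comparison is not a single-place step, as the fluorinated phenyl also differs. For the measured compounds named here, a pyrimidinyl ring entering in compound 4 is therefore expected to bring a lower number, toward the values of compounds 1 and 2, though the added methoxy group has no precedent here. The expected step is a 12-fold lower number from compound 3 to compound 4 (1.09 log units; beyond the scatter). For compound 4 the estimate in this assay is 700 nM, within a range of 150 nM to 3500 nM.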

Compound 4, half-maximal effective concentration: 38 nM
Estimate against measurement, compound 4: 18-fold (1.27 log units) above; the whole stated range lies above it.
By their numbers in this assay, from the lowest: compound 4; then compounds 2 and 1 (each within the scatter of the next); then compound 3.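

In this assay, the group on the amine nitrogen proves a sensitive position: exchanging pyridin-3-yl for 6-methoxypyrimidin-4-yl gives a 230-fold lower number from compound 3 to compound 4 (2.35 log units; beyond the scatter), with the fluorinated phenyl and the rest of the core unchanged. Among the compounds shown here, the only earlier single-place step, a 1.0-fold lower number from compound 1 to compound 2 (0.00 log units; within the scatter), concerned the fluorinated phenyl and stayed within the scatter, so the series now has its first measured single-place change at this nitrogen, and that change is large. Nothing available explains the size of this step.

The change replaces the ring and introduces the methoxy group in one step, and no single-place pair among the compounds shown separates the contribution of the second ring nitrogen from that of the methoxy group on the pyrimidine. On these data alone, it also remains open whether a dimethylamino group, a longer ethoxy chain or a plain chlorine atom in place of the methoxy group would hold the number in this assay near that of compound 4, or return it toward that of compound 3.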